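Adding a Methoxy Group to the Phenyl of Compound 3

This account rests on a few compounds, and the source may have more. Where it says the series, first, only, none or still open, it means among the compounds named here.

Three measured compounds share one core. Compound 1 `COc1cccc(-c2cc3[nH]nc(N)c3c(=O)[nH]2)c1` carries a methoxyphenyl, and in an assay on isolated protein for inhibition of ribosomal protein S6 kinase alpha-1 (Homo sapiens), read by mobility shift assay, tested at 30 uM (on this read-out higher numbers stand for more inhibition at the one concentration tested (going by the name of the read-out) and lower numbers for less inhibition), compound 1 gives 20%. Compound 2 `Cc1cc2c(c(N)nn2C)c(=O)[nH]1` carries a methyl in that position, and in this assay compound 2 gives 2%. Compound 3 `Cn1nc(N)c2c(=O)[nH]c(-c3ccccc3)cc21` carries a plain phenyl, and in this assay compound 3 gives 8%. On these numbers compound 3 stands second highest of three; its nearest neighbour is compound 2, within the scatter, and its furthest is compound 1, beyond the scatter. Within the data shown here, the only single-point step measured is a number 6 percentage points higher from compound 2 to compound 3 (within the scatter), which stays within the scatter.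

Compound 4 `COc1cccc(-c2cc3c(c(N)nn3C)c(=O)[nH]2)c1` differs from compound 3 by methoxy in place of hydrogen on an aromatic carbon. Among the measured compounds shown here, no measured step covers this change alone. Compound 1 and compound 3 differ in two places, and their values show compound 1 higher by an amount beyond the scatter, which gives a loose hint of direction. For compound 4 the expected step is a number 5 percentage points higher from compound 3 to compound 4 (within the scatter), a small rise that may well fall within the scatter. Compound 4 is estimated at 13%, with a range from 2% to 26%.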

Compound 4, a percentage reported as inhibition, at one concentration (the size of the read-out at that concentration, not a potency): 22%
The estimate for compound 4 lay 9 percentage points below the measured number; measured number inside the range.
By their numbers in this assay, from the lowest: compounds 2 and 3 (each within the scatter of the next); then compounds 1 and 4 (each within the scatter of the next).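

In this assay, methoxy in place of hydrogen on the phenyl ring gives a number 14 percentage points higher from compound 3 to compound 4 (beyond the scatter), the first step measured for this change alone and one that clears the usual spread of repeat measurements. With the methoxy in place, methyl in place of hydrogen on the aromatic nitrogen gives a number 2 percentage points higher from compound 1 to compound 4 (within the scatter), so this pair shows no clear effect of that methyl. No measurement here explains why the methoxy group raises the inhibition.

The compounds shown leave open whether the gain is specific to methoxy, since a hydroxy, an ethoxy, an amine or a carboxylic acid at the same place would test that. They also leave open whether methoxy elsewhere on the phenyl ring would do the same, and how potent these compounds are, as each was read at one concentration.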